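Methoxy for ethyl on a urea in a cytotoxicity assay

A few compounds are considered here, and "the series" means these few. Any claim that something is new, unique, unknown or untested is made for them only; others in the source may bear on it.

Measured compounds:
compound 1, `CCc1ccc(NC(=O)Nc2cc(C)nc3ccccc23)cc1`, 16000 nM
compound 2, `Cc1cc(NC(=O)Nc2cccc(N(C)C)c2)c2ccccc2n1`, > 25000 nM

Two ureas on a shared core have been tested in an ADME assay on HEK293 cells (Homo sapiens) for cytotoxicity, with a stated time of 72 h; on this read-out lower numbers stand for an effect already at smaller amounts and higher numbers for an effect only at larger amounts of compound. Within the data shown here, compound 1 gives the only number of the two, 16000 nM. Compound 2 gives no number but a limit of the assay, > 25000 nM. Compound 3, `COc1ccc(NC(=O)Nc2cc(C)nc3ccccc23)cc1`, is not yet measured. It differs from compound 1 by methoxy in place of ethyl on an aromatic carbon. Among the measured compounds shown here, no step between measured compounds is available, so on this change in this assay no shift beyond the usual scatter is expected. Compound 3 is therefore estimated at 20000 nM, between 9000 nM and 40000 nM. This estimate means an expected step of a 1.3-fold higher number from compound 1 to compound 3 (0.10 log units; within the scatter).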

Compound 3, half-maximal effective concentration: > 25000 nM
Compound 3: no number, only a limit; the forecaster's own chance of this, stated with the estimate: 35%; at least 1.2-fold (0.09 log units) between middle value and limit.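

Among these compounds, with methoxy in place of ethyl on an aromatic carbon para to a large group, this assay now gives a first reading for this change: an at least 1.5-fold higher number from compound 1 to compound 3 (0.19 log units; that floor lies within the scatter). The swap gave no lower number at this position, and the value of compound 3 is a limit, not a number. The true size of the step stays hidden because compound 3 sits at the end of the assay's range: the limit of > 25000 nM in this assay, at which 2 of the 3 values shown sit.

Open remains whether an amine or a longer chain at this position would give a measurable number. On these data alone, whether methoxy acts alike elsewhere on the shared core also stays open.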